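The compounds below may be only part of what the source reports. "The series", "measured", "known", "first", "only" and "open" are said of these compounds alone.

Compound 1 `O=C(/C(=C\c1cccc(Cl)c1Cl)SCc1ccc(Cl)cc1)c1ccc(Cl)cc1` and compound 2 `CN(C)c1ccc(/C=C(/SCc2ccc(Cl)cc2)C(=O)c2ccc(Cl)cc2)cc1` share one core and differ in a single group on a double-bonded chain carbon bound to a double-bonded chain carbon. In a functional assay on DU-145 cells (Homo sapiens) for inhibition, read by trypan blue exclusion, with a stated time of 96 h (a lower number here means a stronger inhibitor of growth, a higher number a weaker inhibitor of growth), compound 1 gives 10000 nM. Compound 2 reaches only a limit of this assay, > 100000 nM, so no number is known for it. The step of an at least 10-fold higher number from compound 1 to compound 2 (1.00 log units; beyond the scatter) therefore rests on the limit of > 100000 nM in this assay, at which 1 of the 2 values shown sits, and its true size is open. Compound 3 `Cc1ccc(/C=C(/SCc2ccc(Cl)cc2)C(=O)c2ccc(Cl)cc2)s1` carries the next change at the same place: 5-methylthiophen-2-yl in place of 4-(dimethylamino)phenyl on a double-bonded chain carbon bound to a double-bonded chain carbon. Within the data shown here, only that one measured step bears on it, and it moved from compound 1 up to the limit where compound 2 stands. Moving away from the 4-(dimethylamino)phenyl is expected to bring the number back down, but the amount is uncertain and the step is estimated as an at least 3.3-fold lower number from compound 2 to compound 3 (0.52 log units; beyond the scatter). Compound 3 is expected to give about 30000 nM, within 5000 nM to 150000 nM.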

Compound 3, concentration for 50% growth inhibition: 50000 nM
The estimate for compound 3 lay 1.7-fold (0.22 log units) below the measured number; the range from low to high includes it.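

The 5-methylthiophen-2-yl gives this position its first firm comparison with 2,3-dichlorophenyl: in this assay the change gives a 5.0-fold higher number from compound 1 to compound 3 (0.70 log units; beyond the scatter). Together with the earlier step, this shows two different replacements of 2,3-dichlorophenyl both giving a weaker inhibitor of growth, so among these three compounds compound 1 has the lowest number. Replacing 4-(dimethylamino)phenyl gives an at least 2.0-fold lower number from compound 2 to compound 3 (0.30 log units; that floor lies within the scatter), and the true size of that step stays open because it rests on a limit: the limit of > 100000 nM in this assay, at which 1 of the 3 values shown sits.

With only three groups at this place, the compounds shown leave open which feature of 2,3-dichlorophenyl goes with its lower number. A plain phenyl or a pyridyl group here could help separate the part played by the chlorines from that of the ring itself.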